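A few compounds are considered here, and "the series" means these few. Any claim that something is new, unique, unknown or untested is made for them only; others in the source may bear on it.

Measured so far in a functional assay for inhibition, tested at 40 ug/mL; a lower number here means a weaker effect, a higher number a stronger effect of the compound at the concentration tested:

Compound 1, `Cc1cc(O)c(C(C)C)cc1-c1cc(-c2ccccc2)c(C#N)c(=O)[nH]1`, gives 29%.
Compound 2, `COc1cc(-c2cc(-c3cc(C(C)C)c(O)cc3C)[nH]c(=O)c2C#N)cc(OC)c1OC`, gives 55%.
Compound 3, `COc1cccc(-c2cc(-c3cc(C(C)C)c(O)cc3C)[nH]c(=O)c2C#N)c1`, gives 30%.

Compound 3 stands second highest of these three numbers. Its nearest neighbour is compound 1, from which it differs by a methoxy in place of hydrogen on an aromatic carbon; that step, a number 1 percentage points higher from compound 1 to compound 3 (within the scatter), lies within the scatter, so the two read as alike. Compound 2 stands furthest away, its value higher than that of compound 3 by a margin beyond the scatter.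

The next compound, compound 4, `Cc1cc(O)c(C(C)C)cc1-c1cc(-c2cccs2)c(C#N)c(=O)[nH]1`, arises from compound 3 by a single change: thiophen-2-yl in place of 3-methoxyphenyl on an aromatic carbon. The thiophen-2-yl ring takes the place on the aromatic carbon of the six-membered ring with one nitrogen, ortho to the cyano group, opposite the ring nitrogen.

For the measured compounds named here, no measured step removes or swaps the whole aromatic ring at this place; the only step, from compound 1 to compound 3, merely adds a methoxy and stays within the scatter. Guidance is therefore thin. With compound 1 and compound 3 both near the low end of the range, compound 4 is expected to stay in that region, with a step of about a number 2 percentage points lower from compound 3 to compound 4 (within the scatter), none beyond the scatter.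

The estimate for compound 4 in this assay is 28%, within 12% to 45%.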

Compound 4, a percentage reported as inhibition, at one concentration (the size of the read-out at that concentration, not a potency): 41%
Compound 4: the middle estimate sits 13 percentage points below what was measured; the range from low to high includes it.
By their numbers in this assay, from the lowest: compounds 1 and 3 (each within the scatter of the next); then compound 4; then compound 2.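

In this assay, the ring at this place, ortho to a cyano group and opposite the ring nitrogen, proves able to shift the read-out: thiophen-2-yl in place of 3-methoxyphenyl gives a number 11 percentage points higher from compound 3 to compound 4 (beyond the scatter), and thiophen-2-yl in place of phenyl gives a number 12 percentage points higher from compound 1 to compound 4 (beyond the scatter). Adding a methoxy to the phenyl ring had produced no change beyond the scatter, so these are the first listed steps to do so, and they come from exchanging the whole six-membered ring of carbon for a five-membered aromatic ring with one hetero atom, a modest gain seen from both starting points. Nothing measured alongside these compounds explains the rise.

Still open, on these data alone, is whether the gain belongs to thiophen-2-yl itself or extends to other aromatic rings at this place, such as a furan or a pyridine. Also open, as far as these compounds go, is whether an aromatic ring is needed here at all, which a cyclohexyl ring or an aminomethyl group at the same carbon would help to settle.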